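The compounds below may be only part of what the source reports. "The series", "measured", "known", "first", "only" and "open" are said of these compounds alone.

Working notes on the series. In a physicochemical assay for solubility, read by HPLC (on this read-out higher numbers stand for higher solubility and lower numbers for lower solubility), compound 2 (`CN(CCOC(=O)ONC(=O)/C=C/c1cccc(S(=O)(=O)Nc2ccccc2)c1)C(=O)OCc1ccc(O[C@@H]2O[C@H](C(=O)O)[C@@H](O)[C@H](O)[C@H]2O)c([N+](=O)[O-])c1`) reads 80000 ug/mL against compound 1 (`CN(CCOC(=O)ONC(=O)CCCCCCC(=O)Nc1ccccc1)C(=O)OCc1ccc(O[C@@H]2O[C@H](C(=O)O)[C@@H](O)[C@H](O)[C@H]2O)c(N)c1`) at 55000 ug/mL and these two numbers lie within the scatter of each other, so compound 2 has no standing apart from compound 1 on present data. The next entry is compound 3 (`CN(CCOC(=O)ONC(=O)/C=C/c1cccc(S(=O)(=O)Nc2ccccc2)c1)C(=O)OCc1ccc(O[C@@H]2O[C@H](C(=O)O)[C@@H](O)[C@H](O)[C@H]2O)c(N)c1`), which has amino in place of nitro on an aromatic carbon and this carbon is ortho to a large group and meta to a large group. Within the data shown here, no measured pair isolates this change, and the data offer no direct precedent for it. With so little to go on, no step beyond the scatter is expected in this assay and no firm direction can be given. The estimated move is a 1.2-fold lower number from compound 2 to compound 3 (0.09 log units; within the scatter) and it is expected to stay within the scatter. Compound 3 is expected at 65000 ug/mL with an estimated range from 30000 ug/mL to 130000 ug/mL as the working figure.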

Compound 3, solubility: 100000 ug/mL
For compound 3 the middle estimate is 1.5-fold (0.19 log units) below the measured one; measured number inside the range.
By their numbers in this assay, from the lowest: compounds 1, 2 and 3 (each within the scatter of the next).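

In this assay, amino in place of nitro on an aromatic carbon, ortho to a large group and meta to a large group, gives a 1.3-fold higher number from compound 2 to compound 3 (0.10 log units; within the scatter). Among these compounds, this is the first pair that isolates this change, and the two compounds cannot be told apart on this read-out. At this position, on this background, nitro and amino are therefore interchangeable as far as this assay can show, and no measurement given here bears on the reason. As far as these compounds go, whether a hydroxyl, a fluorine or a dimethylamino group on the same aromatic carbon would also fall within the scatter of compound 3 remains open. Also open, from the compounds shown here alone, is whether the same change gives the same result with a longer chain in place of the unsaturated linker of compound 3.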